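Replacing the nitrile with a pyridinyloxy group on the shared core

The source may hold more compounds than are shown below. What is called first, only, known or untested is meant among the compounds shown, and "the series" means these compounds.

Compound 1: `CCCCCc1cc(C)c(C(=O)N=C(N)N)cc1S(C)(=O)=O`, 27 nM
Compound 2: `Cc1cc(OC(C)C)c(S(C)(=O)=O)cc1C(=O)N=C(N)N`, 19 nM
Compound 3: `Cc1cc(C#N)c(S(C)(=O)=O)cc1C(=O)N=C(N)N`, 70 nM

These three compounds share one core and differ only in a single group on an aromatic carbon. In a functional assay for inhibition of sodium/hydrogen exchanger (Oryctolagus cuniculus) (on this read-out lower numbers stand for stronger inhibition and higher numbers for weaker inhibition), compound 3 gives 70 nM, the highest number of the three; the steps of a 2.6-fold higher number from compound 1 to compound 3 (0.41 log units; beyond the scatter) and a 3.7-fold higher number from compound 2 to compound 3 (0.57 log units; beyond the scatter) both lie beyond the scatter, while a 1.4-fold lower number from compound 1 to compound 2 (0.15 log units; within the scatter) does not.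

Compound 4 is `Cc1cc(Oc2cccnc2)c(S(C)(=O)=O)cc1C(=O)N=C(N)N`. The change from compound 3 is (pyridin-3-yl)oxy in place of cyano on an aromatic carbon. Within the data shown here, two measured steps bear on this: a 3.7-fold higher number from compound 2 to compound 3 (0.57 log units; beyond the scatter) and a 2.6-fold higher number from compound 1 to compound 3 (0.41 log units; beyond the scatter) show that the cyano group gives a higher number than either the isopropoxy or the pentyl group at this position. Compound 4 carries an oxygen-linked group again, as compound 2 does, so the step from compound 3 to compound 4 is expected to run in the opposite direction from those two steps, giving a lower number of modest size. The estimate is a 2.8-fold lower number from compound 3 to compound 4 (0.45 log units; beyond the scatter). Compound 4 is therefore expected to give about 25 nM in this assay, with a range from 10 nM to 70 nM.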

Compound 4, half-maximal inhibitory concentration: 8.8 nM
Beside the measured number, compound 4's estimate is 2.8-fold (0.45 log units) above it, and the stated range ends above it.
By their numbers in this assay, from the lowest: compound 4; then compounds 2 and 1 (each within the scatter of the next); then compound 3.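

At the aromatic carbon ortho to a methylsulfonyl group, putting (pyridin-3-yl)oxy in place of cyano gives an 8.0-fold lower number from compound 3 to compound 4 (0.90 log units; beyond the scatter) in this assay, so this position accepts a group carrying a six-membered aromatic ring. The earlier compounds shown here carried only cyano and the open-chain isopropoxy and pentyl groups here, and those two open-chain groups lay within the scatter of each other; the ring-bearing group separates from both, with a 2.2-fold lower number from compound 2 to compound 4 (0.33 log units; beyond the scatter) and a 3.1-fold lower number from compound 1 to compound 4 (0.49 log units; beyond the scatter), which makes compound 4 the strongest inhibitor of the four. The step from compound 2 is the most telling, since the oxygen stays in place and only the group on it changes, from isopropyl to pyridin-3-yl.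

No measurement shown here explains why the number falls with this change. These compounds also cannot separate the contributions of the ring, its nitrogen and the oxygen link, which would take a comparison with a phenoxy group, a pyridin-4-yloxy group or a pyridin-3-yl ring attached directly to the aromatic carbon.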